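The source may hold more compounds than are shown below. What is called first, only, known or untested is meant among the compounds shown, and "the series" means these compounds.

Measured compounds in a functional assay on 1321-N1 cells for agonist activity at P2Y purinoceptor 4 (Homo sapiens), read by scintillation counting and inositol phosphate accumulation; on this read-out higher numbers stand for an effect only at larger amounts of compound and lower numbers for an effect already at smaller amounts:

compound 1 `O=C(O)CCCO/N=c1/ccn([C@@H]2O[C@H](COP(=O)(O)OP(=O)(O)OP(=O)(O)O)[C@@H](O)[C@H]2O)c(=O)[nH]1`: 470 nM
compound 2 `O=c1[nH]/c(=N\OCCCc2ccc(F)cc2)ccn1[C@@H]1O[C@H](COP(=O)(O)OP(=O)(O)OP(=O)(O)O)[C@@H](O)[C@H]1O`: 105 nM
compound 3 `O=c1[nH]/c(=N\OCCCc2ccc([N+](=O)[O-])cc2)ccn1[C@@H]1O[C@H](COP(=O)(O)OP(=O)(O)OP(=O)(O)O)[C@@H](O)[C@H]1O`: 84 nM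

Compound 3 gives the lowest number of the three. Its gap to compound 2 is within the scatter, so the two cannot be ordered; its gap to compound 1 is beyond the scatter, as a 5.6-fold lower number from compound 1 to compound 3 (0.75 log units; beyond the scatter) shows.

Compound 4 `O=c1[nH]/c(=N\OCCCc2ccsc2)ccn1[C@@H]1O[C@H](COP(=O)(O)OP(=O)(O)OP(=O)(O)O)[C@@H](O)[C@H]1O` is not yet measured. It differs from compound 3 in one place: thiophen-3-yl in place of 4-nitrophenyl on a saturated chain carbon, three bonds along the chain from an oxygen.

For the measured compounds named here, two measured steps bear on this. Both a 4.5-fold lower number from compound 1 to compound 2 (0.65 log units; beyond the scatter) and a 5.6-fold lower number from compound 1 to compound 3 (0.75 log units; beyond the scatter) show that an aromatic ring at this position, in place of carboxy, brings a modest drop in the number. The step of a 1.3-fold lower number from compound 2 to compound 3 (0.10 log units; within the scatter) shows that exchanging one aromatic substituent for another at this position leaves the number within the scatter. Thiophen-3-yl is a smaller aromatic ring without a substituent, so the outcome is expected to resemble compound 2 and compound 3 rather than compound 1, with at most a small rise in the number; the step from compound 3 is expected to be a 1.5-fold higher number from compound 3 to compound 4 (0.19 log units; within the scatter). For compound 4 in this assay the estimate is 130 nM, with a range from 50 nM to 350 nM.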

Compound 4, half-maximal effective concentration: 20 nM
For compound 4 the middle estimate is 6.5-fold (0.81 log units) above the measured one, and the stated range ends above it.
By their numbers in this assay, from the lowest: compound 4; then compounds 3 and 2 (each within the scatter of the next); then compound 1.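

In this assay, for the compounds shown here, the two substituted phenyl rings could not be told apart at this position, but thiophen-3-yl is the first exchange of one aromatic group for another on this saturated chain carbon, three bonds along the chain from an oxygen, to move the number beyond the scatter (a 4.2-fold lower number from compound 3 to compound 4 (0.62 log units; beyond the scatter); a 5.3-fold lower number from compound 2 to compound 4 (0.72 log units; beyond the scatter)). The identity of the aromatic ring therefore matters here, and the loss of the benzene ring and its substituent, with fewer heavy atoms in the group, carries no penalty in this series, while the replacement of carboxy now reaches a large step (a 24-fold lower number from compound 1 to compound 4 (1.37 log units; beyond the scatter)) rather than the modest ones seen with compound 2 and compound 3. Nothing measured on these compounds accounts for the step from the aromatic rings to thiophen-3-yl.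

Still open, on these data alone, is whether the lower number belongs to the sulfur-containing ring or simply to the absence of a substituent, a question that an unsubstituted phenyl or a furan-3-yl on the same propyl chain would address. Also open, as far as these compounds go, is how thiophen-3-yl behaves on a shorter chain such as 2-(thiophen-3-yl)ethyl or on a longer chain, and whether thiophen-2-yl gives the same result.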